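The source may hold more compounds than are shown below. What is called first, only, known or untested is meant among the compounds shown, and "the series" means these compounds.

Compound 1 `COc1cc(-c2nccn2C(C)C)cc(OC)c1OC` gives > 100000 nM (a limit of the assay)
Compound 2 `COc1cc(-c2nccn2-c2ccc(C)cc2)cc(OC)c1OC` gives 20500 nM
Compound 3 `COc1cc(-c2nccn2-c2cccc(C)c2)cc(OC)c1OC` gives 29300 nM

All three were read in a functional assay on T47D cells (Homo sapiens) for antiproliferative activity, read by MTT assay, with a stated time of 72 h; on this read-out lower numbers stand for stronger inhibition and higher numbers for weaker inhibition. Within the data shown here, compound 3 stands within the scatter of its one numerical neighbour and clear of the limit. The steps are a 1.4-fold higher number from compound 2 to compound 3 (0.16 log units; within the scatter) and an at least 3.4-fold lower number from compound 1 to compound 3 (0.53 log units; beyond the scatter). Compound 4 `COc1cc(-c2nccn2-c2cccc([N+](=O)[O-])c2)cc(OC)c1OC` has nitro in place of methyl on an aromatic carbon, meta to a large group (nitro in place of methyl on an aromatic carbon). The other step away from isopropyl (an at least 4.8-fold lower number from compound 1 to compound 2 (0.68 log units; beyond the scatter)) is a different change. Only the shift of the methyl group touches this substituent, and it stayed within the scatter. Among the measured compounds shown here, no measured step replaces methyl itself, so the expectation in this assay is no step beyond the scatter, held loosely. The expected step is a 1.2-fold lower number from compound 3 to compound 4 (0.07 log units; within the scatter). For compound 4 the estimated value is 25000 nM, with an expected range of 8000 nM to 75000 nM.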

Compound 4, half-maximal inhibitory concentration: 17900 nM
The estimate for compound 4 lay 1.4-fold (0.15 log units) above the measured number; measured number inside the range.
By their numbers in this assay, from the lowest: compounds 4, 2 and 3 (each within the scatter of the next). At a limit, above all of these: compound 1.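

In this assay, nitro in place of methyl on an aromatic carbon, meta to a large group, gives a 1.6-fold lower number from compound 3 to compound 4 (0.21 log units; within the scatter). Earlier, this place had only seen the methyl group shifted; now the group itself has been exchanged, and the entry of nitro, with its two hydrogen-bond acceptors, leaves the number within the scatter. Nothing at hand bears on a cause for this step. As far as these compounds go, whether an amine or a carboxylic acid here would move the number beyond the scatter stays open. So does whether any group at this place can do so.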